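Reversing the Amide Link in a Prostaglandin Receptor Ligand Series

The source may hold more compounds than are shown below. What is called first, only, known or untested is meant among the compounds shown, and "the series" means these compounds.

Measured so far:
- compound 1 `Cc1cc(C(=O)Nc2c(F)cccc2F)nn1Cc1cc(Cl)ccc1OCc1ccccc1`: 10 nM
- compound 2 `Cc1cc(C(=O)Nc2ccccn2)nn1Cc1cc(Cl)ccc1OCc1ccccc1`: 126 nM

Both were tested in an assay on CHO-K1 cells for displacement of a labelled ligand from prostaglandin E2 receptor EP1 subtype (Homo sapiens); on this read-out higher numbers stand for weaker inhibition and lower numbers for stronger inhibition. Compound 1 gives 10 nM and stands lowest of the two numbers; compound 2 gives 126 nM, a weaker result. For the measured compounds named here, the one measured step, a 13-fold higher number from compound 1 to compound 2 (1.10 log units; beyond the scatter), shows that swapping the aromatic group on the amide-type nitrogen alone can move the number a long way.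

Compound 3 `Cc1cc(NC(=O)c2ccccc2)nn1Cc1cc(Cl)ccc1OCc1ccccc1` has not yet been measured. It differs from compound 1 by benzamido in place of (2,6-difluorophenyl)carbamoyl on an aromatic carbon. Here the amide is turned around: the ring of the shared core now carries the nitrogen of the amide, and the carbonyl sits on the outer phenyl ring, which also loses its two fluorine atoms. Going by the values given here, no measured pair shows this kind of reversal, so the step from compound 1 to compound 2 is only a loose guide: it shows that changes at this end of the molecule are felt strongly in this assay. A weaker result than compound 1 is therefore the more likely outcome, with wide uncertainty. Compound 3 is expected to give 150 nM, in a range from 20 nM to 1500 nM, which would mean a step of a 15-fold higher number from compound 1 to compound 3 (1.18 log units; beyond the scatter).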

Compound 3, half-maximal inhibitory concentration: 15.9 nM
For compound 3 the middle estimate is 9.4-fold (0.97 log units) above the measured one, outside the stated range (below it).
By their numbers in this assay, from the lowest: compounds 1 and 3 (each within the scatter of the next); then compound 2.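

In this assay, turning the amide around and losing the two fluorine atoms together leave the number within the usual scatter, a 1.6-fold higher number from compound 1 to compound 3 (0.20 log units; within the scatter), so benzamido can stand in for (2,6-difluorophenyl)carbamoyl on this aromatic carbon of the shared core. The comparison with the pyridine amide points the other way, a 7.9-fold lower number from compound 2 to compound 3 (0.90 log units; beyond the scatter), which shows that the large drop seen with the pyridin-2-yl group does not hold for every change at this end of the molecule. No measurement at hand explains why the two amide directions read alike here.

The compounds shown cannot separate the effect of the turned amide from that of the lost fluorine atoms, and a 2,6-difluorobenzamido group or a plain phenylcarbamoyl group would pull these two changes apart. Also open, as far as these compounds go, is how the outer phenyl ring of the benzamido group responds to other substituents, such as a carboxylic acid or an amine.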